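A Longer Chain on a Nitrogen in an Inactive Pair

The source may report more compounds than this note shows. Statements on the series, on what has been measured and on what is new or still open speak of the compounds shown alone.

In a functional assay on T47D cells (Homo sapiens) for antiproliferative activity, read by MTT assay, with a stated time of 72 h (a lower number here means a stronger inhibitor, a higher number a weaker inhibitor), compound 1 (`COc1cc(-c2nccn2C)cc(OC)c1OC`) gives > 100000 nM, which is a limit and not a number. In this assay, compound 2 (`COc1cc(-c2nccn2C(C)C)cc(OC)c1OC`) gives > 100000 nM, which is also a limit. Compound 2 therefore offers no measured number from which to start.

The next compound, compound 3 (`CCCCn1ccnc1-c1cc(OC)c(OC)c(OC)c1`), carries butyl in place of isopropyl on an aromatic nitrogen. The counted difference is butyl in place of isopropyl on an aromatic nitrogen.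

Within the data shown here, only one measured step bears on this change, as it alters the group on that same nitrogen: a step that the two limits leave unreadable from compound 1 to compound 2. Its size cannot be read, so it gives no direction for a further change. All the evidence so far is the limit of > 100000 nM in this assay, at which 2 of the 2 values shown sit. On that basis, no step beyond the usual scatter is expected in this assay, and another limit is the most likely result.

The step expected from this estimate is a number no higher from compound 2 to compound 3 (the limit leaves the size open). For compound 3, the estimated value is 100000 nM, with an expected range from 40000 nM to 250000 nM.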

Compound 3, half-maximal inhibitory concentration: > 100000 nM
Compound 3 was reported as a limit; the forecaster's own chance of this, stated with the estimate: 80%; the middle value sits exactly at the limit.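

In this assay compound 3 gives > 100000 nM as a limit and not a number. Its steps from compound 1 and from compound 2 therefore cannot be read, and the evidence remains a single limit: the limit of > 100000 nM in this assay, at which 3 of the 3 values shown sit. The compounds shown leave open whether any group on that nitrogen gives a measurable number in this assay.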